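Pyridyl swap on two cores: cytotoxicity notes

A few compounds are considered here, and "the series" means these few. Any claim that something is new, unique, unknown or untested is made for them only; others in the source may bear on it.

Measured so far in an ADME assay on HeLa cells (Homo sapiens) for cytotoxicity, read by XTT assay, with a stated time of 3 days; on this read-out higher numbers stand for lower toxicity in this test and lower numbers for higher toxicity in this test:
compound 1 `C1=C(/C=C/c2ccccn2)COc2ccccc21` gives > 50000 nM, which is a limit of the test.
compound 2 `C1=C(/C=C/c2ccncc2)COc2ccccc21` gives 75000 nM.
compound 3 `O=c1c(/C=C/c2ccccn2)coc2ccccc12` gives > 200000 nM, which is a limit of the test.

The change from compound 1 to compound 2 is pyridin-4-yl in place of pyridin-2-yl on a double-bonded chain carbon bound to a double-bonded chain carbon; the step that the limit leaves unreadable from compound 1 to compound 2 is left unreadable by the limit of > 50000 nM in this assay, at which 1 of the 3 values shown sits. Compound 4 `O=c1c(/C=C/c2ccncc2)coc2ccccc12` carries the same change on the core of compound 3, (pyridin-4-yl in place of pyridin-2-yl on a double-bonded chain carbon bound to a double-bonded chain carbon); the difference between the two cores is not broken down here. Within the data shown here, the only readable number, from compound 2, sits near the limits, and compound 3 sits at the limit of > 200000 nM in this assay, at which 1 of the 3 values shown sits. For compound 4 the step of a number no higher from compound 3 to compound 4 (the limit leaves the size open) is therefore expected to be small. Compound 4 is estimated at 200000 nM in this assay, with a fair chance that only a limit is reported.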

Compound 4, half-maximal cytotoxic concentration: > 100000 nM
Compound 4 was reported as a limit; the forecaster's own chance of this, stated with the estimate: 60%; the middle value does not contradict the limit.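

Compound 3 and compound 4 both stand as limits in this assay, and no step can be read between them. The compounds shown leave open how far pyridin-4-yl in place of pyridin-2-yl shifts cytotoxicity on either core.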